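Methyl to Bromo on the Sulfonyl Aryl Ring

The source may hold more compounds than are shown below. What is called first, only, known or untested is meant among the compounds shown, and "the series" means these compounds.

Measured compounds:
compound 1, `Cc1ccc(S(=O)(=O)NC(=O)c2ccc(Cl)nc2)cc1`, 17200 nM
compound 2, `O=C(NS(=O)(=O)c1ccc(Br)cc1)c1ccc(Cl)nc1`, 9050 nM
compound 3, `Cc1ccc(S(=O)(=O)NC(=O)c2ccc(C)nc2Cl)cc1`, 8520 nM

All three compounds were tested in a functional assay on MCF7 cells (Homo sapiens) for antiproliferative activity, read by MTT assay, with a stated time of 48 h; a lower number here means a stronger inhibitor, a higher number a weaker inhibitor. Compound 1 gives 17200 nM, compound 2 gives 9050 nM and compound 3 gives 8520 nM. Compound 2 and compound 3 lie within the scatter of each other, so no order between them can be read. Compound 1 stands a little apart from compound 3, beyond the scatter.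

The pair compound 1 and compound 2 differ in one place only: bromo in place of methyl on an aromatic carbon. This gave a 1.9-fold lower number from compound 1 to compound 2 (0.28 log units; within the scatter). The same change, at the same kind of place, separates compound 3 from compound 4, which has the structure `Cc1ccc(C(=O)NS(=O)(=O)c2ccc(Br)cc2)c(Cl)n1` and is not yet measured: bromo in place of methyl on an aromatic carbon. The difference between the core of compound 1 and the core of compound 3 is not broken down here.

Since the change from compound 3 to compound 4 is the same one that was already measured once, the expectation rests on that single earlier step. In this assay compound 4 is expected to show a 1.8-fold lower number from compound 3 to compound 4 (0.25 log units; within the scatter), in line with what compound 2 showed against compound 1 through a 1.9-fold lower number from compound 1 to compound 2 (0.28 log units; within the scatter), a step that itself fell within the scatter. Within the data shown here, with only one prior example, a result anywhere near the value of compound 3 would also fit. The estimate for compound 4 is 4800 nM, expected to fall between 2000 nM and 11000 nM.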

Compound 4, half-maximal inhibitory concentration: 1970 nM
Beside the measured number, compound 4's estimate is 2.4-fold (0.39 log units) above it, and the stated range ends above it.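

In this assay, bromo in place of methyl on the aromatic ring, the change from 4-methylphenyl to 4-bromophenyl, gave a 4.3-fold lower number from compound 3 to compound 4 (0.64 log units; beyond the scatter). This points the same way as the earlier step on the core of compound 1, although that earlier step alone lay within the scatter and could not have been trusted by itself. Set side by side, the two steps cannot be told apart in size, even though their numbers look different: the same change on two cores in this assay, a 1.9-fold lower number (0.28 log units; within the scatter) from compound 1 to compound 2 and a 4.3-fold lower number (0.64 log units; beyond the scatter) from compound 3 to compound 4, 2.3-fold (0.36 log units) apart, within the scatter of two such steps. So this pair of steps supports the idea that the change carries over from one core to the other, but it does not show that the core of compound 3 gains more from bromo than the core of compound 1 does, and two cores are too few to make a rule for the whole series.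

The compounds shown leave open how other groups at this same place, such as fluoro, methoxy or an amine, would compare with bromo and methyl. They also leave open how the difference between the two cores acts on its own, since that difference is not broken down into single changes here.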